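Replacing the vinyl group of compound 3

A few compounds are considered here, and "the series" means these few. Any claim that something is new, unique, unknown or untested is made for them only; others in the source may bear on it.

In a functional assay on MCF7 cells (Homo sapiens) for antiproliferative activity, read by MTT assay, with a stated time of 72 h (on this read-out lower numbers stand for stronger inhibition and higher numbers for weaker inhibition), three compounds sharing one core have been measured. Compound 1 `C=CC(=O)Nc1cccc(Oc2nc(Nc3cccc(C#N)c3)nc3c2CSCC3)c1` gives 21700 nM, compound 2 `C=CC(=O)Nc1cccc(Oc2nc(Nc3ccc(OC)cc3)nc3c2CSCC3)c1` gives 11700 nM, and compound 3 `C=CC(=O)Nc1cccc(Oc2nc(Nc3ccc(OC)nc3)nc3c2CSCC3)c1` gives 17200 nM. Compound 3 thus stands within the scatter of both other compounds, so no order among the three can be claimed. Compound 4 `COc1ccc(Nc2nc3c(c(Oc4cccc(NC(=O)/C=C/C(C)C)c4)n2)CSCC3)cn1` keeps the 6-methoxypyridin-3-yl group of compound 3 and differs in another place, with 3-methylbut-1-en-1-yl in place of vinyl on a carbonyl carbon.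

The measured steps bear on this change only indirectly. All three alter the group on a nitrogen on an aromatic ring, not the group on the carbonyl carbon: a 1.9-fold lower number from compound 1 to compound 2 (0.27 log units; within the scatter), a 1.3-fold lower number from compound 1 to compound 3 (0.10 log units; within the scatter) and a 1.5-fold higher number from compound 2 to compound 3 (0.17 log units; within the scatter). Each lies within the scatter, and none tests the new change, so the data give no direct measure of its size or direction. With the value of compound 3 as the only anchor, no step beyond the scatter is expected in this assay, though the uncertainty is wide. The expected step is a 1.2-fold higher number from compound 3 to compound 4 (0.07 log units; within the scatter). For compound 4 the estimated value is 20000 nM, with an expected range from 9000 nM to 45000 nM.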

Compound 4, half-maximal inhibitory concentration: 37100 nM
The estimate for compound 4 lay 1.9-fold (0.27 log units) below the measured number, within the range that was stated.
By their numbers in this assay, from the lowest: compounds 2, 3, 1 and 4 (each within the scatter of the next, the first and the last beyond it).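

Among these compounds, the change from vinyl to 3-methylbut-1-en-1-yl, on a carbonyl carbon whose other neighbour is an amide-type nitrogen, gives the only step at this position in this assay: a 2.2-fold higher number from compound 3 to compound 4 (0.33 log units; beyond the scatter). The earlier steps shown here all altered the group on a nitrogen on an aromatic ring and stayed within the scatter, whereas this single pair shows that the group on the carbonyl carbon can move the number, here modestly towards weaker inhibition, as the group goes from 2 heavy atoms to 5 and keeps its 1 double bond outside aromatic rings. No measurement available here accounts for this step.

With one pair, the compounds shown leave open whether the size of the new group, its branching or some other feature of it matters, and whether the same change would give a similar step with the 4-methoxyphenyl group of compound 2 or the 3-cyanophenyl group of compound 1. They also leave open how an ethyl group, a straight propenyl chain or a dimethylamine-bearing chain on the same carbonyl carbon would read in this assay.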